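The source may report more compounds than this note shows. Statements on the series, on what has been measured and on what is new or still open speak of the compounds shown alone.

Measured in an ADME assay on microsomes from liver (Rattus norvegicus) for metabolic stability; a lower number here means slower removal, a higher number faster removal of the compound:
compound 1 `CNc1nc(NC2(C#N)CCCC(C)C2)nc(-n2cncn2)n1`: 96 mL/min/kg
compound 2 `CNc1nc(NC2(C#N)CCCCC2)nc(-n2cncn2)n1`: 52 mL/min/kg
compound 3 `CCC(C)(C#N)Nc1nc(NC)nc(-n2cncn2)n1`: 32 mL/min/kg

Compound 2, at 52 mL/min/kg, holds the middle place among these three numbers, and it lies within the usual scatter of each of the other two. Repeat measurements of this kind could therefore change how those neighbours line up.

The next compound to be tested is compound 4 `CNc1nc(Cl)nc(NC2(C#N)CCCCC2)n1`. Its structure departs from compound 2 at one place: chloro in place of 1H-1,2,4-triazol-1-yl on an aromatic carbon. In words, this is chloro in place of 1H-1,2,4-triazol-1-yl on an aromatic carbon.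

The measured data offer little guidance on this swap. All three measured compounds carry the 1H-1,2,4-triazol-1-yl group, so none of them shows what removing it does. Among the measured compounds shown here, the one measured step, a 1.8-fold lower number from compound 1 to compound 2 (0.27 log units; within the scatter), is a hydrogen in place of methyl on a saturated ring carbon, at a different part of the molecule. It stays within the scatter and gives only a rough sense of how far one small edit moved this series.

With no evidence for a direction, the expected result in this assay is no step beyond the scatter, and the estimated step is a 1.1-fold higher number from compound 2 to compound 4 (0.02 log units; within the scatter). Compound 4 is estimated at 55 mL/min/kg, with an expected range from 24 mL/min/kg to 125 mL/min/kg.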

Compound 4, clearance: 867 mL/min/kg
Beside the measured number, compound 4's estimate is 16-fold (1.20 log units) below it; the whole stated range lies below it.
By their numbers in this assay, from the lowest: compounds 3, 2 and 1 (each within the scatter of the next, the first and the last beyond it); then compound 4.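

In this assay, the aromatic carbon opposite the ring nitrogen proves far more sensitive than the saturated ring carbon of the earlier comparison: chloro in place of 1H-1,2,4-triazol-1-yl gives a 17-fold higher number from compound 2 to compound 4 (1.22 log units; beyond the scatter), whereas hydrogen in place of methyl gave only a 1.8-fold lower number from compound 1 to compound 2 (0.27 log units; within the scatter). This single edit changes several things at once, as a five-membered aromatic ring with 3 hetero atoms and 3 hydrogen-bond acceptors leaves and a lone chlorine atom with no ring and no hydrogen-bond acceptors enters. No measurement among those shown explains why removal is so much faster with this swap.

With only these two groups shown at this carbon, it remains open whether the large step comes from losing the 1H-1,2,4-triazol-1-yl group, from gaining the chloro group, or from both. A plain hydrogen, a methoxy group, a dimethylamino group or a pyrazol-1-yl ring at the same position could help separate these possibilities, and the same swap on the core of compound 3 could test whether the step carries over to another amino side group.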